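Cyclobutyl to cyclohexyl on the ether side chain

The source may report more compounds than this note shows. Statements on the series, on what has been measured and on what is new or still open speak of the compounds shown alone.

- compound 1 `Cc1cccc(C)c1COC(c1ccc([C@]2(S(=O)(=O)c3ccc(F)cc3)CCN(C(=O)[C@H]3CC[C@H](C(=O)O)CC3)C2)cc1)(C(F)(F)F)C(F)(F)F` gives 77%
- compound 2 `O=C(O)[C@H]1CC[C@H](C(=O)N2CC[C@](c3ccc(C(OCc4c(F)cccc4Cl)(C(F)(F)F)C(F)(F)F)cc3)(S(=O)(=O)c3ccc(F)cc3)C2)CC1` gives 87%
- compound 3 `O=C(O)[C@H]1CC[C@H](C(=O)N2CC[C@](c3ccc(C(OCC4CCC4)(C(F)(F)F)C(F)(F)F)cc3)(S(=O)(=O)c3ccc(F)cc3)C2)CC1` gives 39%
- compound 4 `O=C(O)[C@H]1CC[C@H](C(=O)N2CC[C@](c3ccc(C(OCC4CCCCC4)(C(F)(F)F)C(F)(F)F)cc3)(S(=O)(=O)c3ccc(F)cc3)C2)CC1` is not yet measured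

Compound 3 stands lowest of the three measured compounds in an ADME assay on microsomes from liver (Mus musculus) for metabolic stability, with a stated time of 10 min (on this read-out higher numbers stand for a more stable compound and lower numbers for a less stable compound), at 39% and serves as the reference here. Compound 4 keeps the shared core and changes one group: cyclohexyl in place of cyclobutyl on a saturated chain carbon bound to an oxygen on a saturated carbon.

The measured steps at this place are a number 38 percentage points lower from compound 1 to compound 3 (beyond the scatter) and a number 48 percentage points lower from compound 2 to compound 3 (beyond the scatter) and both are large, each putting cyclobutyl in place of a substituted phenyl. Between the two phenyl groups the step is a number 10 percentage points higher from compound 1 to compound 2 (within the scatter) and so gives no separation. None of these exchanges one non-aromatic ring for another, so the data set no direct size for this change. Within the data shown here, compound 3 at 39% is the only measured compound with a non-aromatic ring in this place, so the expectation starts from that value. A step well short of the two large ones is expected, leaning slightly lower, and it may stay within the scatter. The expected step is a number 6 percentage points lower from compound 3 to compound 4 (within the scatter) by this estimate. In this assay the estimate for compound 4 is 33% with an expected range from 15% to 55% for a single measurement.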

Compound 4, percent of the compound remaining: 78%
Compound 4: middle estimate off by 45 percentage points, on the low side, and the stated range ends below it.
By their numbers in this assay, from the lowest: compound 3; then compounds 1, 4 and 2 (each within the scatter of the next).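

In this assay, the size of the non-aromatic ring on a saturated chain carbon bound to an oxygen on a saturated carbon matters a great deal: cyclohexyl in place of cyclobutyl gives a large step (a number 39 percentage points higher from compound 3 to compound 4 (beyond the scatter)). Among these compounds, the low value of compound 3 therefore does not hold for non-aromatic rings at this place in general, as cyclohexyl shows no separation from either substituted phenyl group, whether it replaces 2-chloro-6-fluorophenyl (a number 9 percentage points lower from compound 2 to compound 4 (within the scatter)) or 2,6-dimethylphenyl (a number 1 percentage points higher from compound 1 to compound 4 (within the scatter)), leaving cyclobutyl as the only one of the four groups set apart. Nothing at hand bears on the reason for the gap between the two rings.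

Going by these compounds, two non-aromatic rings do not define a trend with ring size, so cyclopentyl and an open chain such as a longer alkyl chain remain open at this place. Also open, on these data alone, is whether a six-membered ring carrying an amine or a ring oxygen, such as piperidinyl or tetrahydropyranyl, would stay with cyclohexyl or fall towards cyclobutyl in this assay.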